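Lengthening the Aryl Ether Chain: Compound 2 to Compound 3

This account rests on a few compounds, and the source may have more. Where it says the series, first, only, none or still open, it means among the compounds named here.

Measured compounds:
compound 1, `Cc1cc(C)c(CNC(=O)c2cccc(OC(C)C)c2C)c(=O)[nH]1`: 1400 nM
compound 2, `COc1cccc(C(=O)NCc2c(C)cc(C)[nH]c2=O)c1C`: 5700 nM

Of the compounds shown here, two have been measured in an assay on Sf9 cells for inhibition of histone-lysine N-methyltransferase EZH2 (Homo sapiens), read by scintillation counting, with a stated time of 60 min, in the presence of a further agent that is not named here (a higher number here means a weaker inhibitor, a lower number a stronger inhibitor), and they share one core. Compound 1 carries an isopropoxy group on its aromatic ring and gives 1400 nM. Compound 2 carries a methoxy group at that place and gives 5700 nM. For the measured compounds named here, the only measured step is a 4.1-fold higher number from compound 1 to compound 2 (0.61 log units; beyond the scatter), so compound 2 stands at the highest of the two numbers, with compound 1 as its only neighbour.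

Compound 3, `CCOc1cccc(C(=O)NCc2c(C)cc(C)[nH]c2=O)c1C`, has not yet been measured. The change from compound 2 is methyl in place of hydrogen on a saturated chain carbon bound to an oxygen on an aromatic ring, which reads methoxy to ethoxy one bond further out. Going by the values given here, the only step that bears on it is a 4.1-fold higher number from compound 1 to compound 2 (0.61 log units; beyond the scatter), which runs in the opposite direction, from a larger to a smaller alkyl group on the oxygen. Going back toward the larger group, a decrease in this assay is therefore expected for compound 3, likely smaller than that step since the ethyl group is one carbon short of isopropyl; the expected step is a 2.0-fold lower number from compound 2 to compound 3 (0.31 log units; beyond the scatter). The expected value for compound 3 is 2800 nM, with a range from 1200 nM to 6500 nM.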

Compound 3, half-maximal inhibitory concentration: 2000 nM
For compound 3 the middle estimate is 1.4-fold (0.15 log units) above the measured one; low and high end bracket the measured number.
By their numbers in this assay, from the lowest: compounds 1 and 3 (each within the scatter of the next); then compound 2.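

In this assay, going from methoxy to ethoxy gives a 2.9-fold lower number from compound 2 to compound 3 (0.45 log units; beyond the scatter), which shows that the difference seen earlier between the methoxy and isopropoxy groups does not depend on a branched group: a single added methyl on the saturated chain carbon bound to the oxygen already gives a step beyond the scatter. The comparison with the branched group gives a 1.4-fold higher number from compound 1 to compound 3 (0.15 log units; within the scatter), so this assay does not separate the ethoxy and isopropoxy groups. Among these three compounds, the measurable change at this position therefore lies in the step from methoxy to ethoxy, while the further step to isopropoxy stays within the scatter.

The compounds shown leave open whether a longer chain such as propoxy or butoxy, or a ring-bearing group such as cyclopropylmethoxy, would keep, lower or raise the number. They also leave open what a free hydroxyl or an amine would do at this place, since all three compounds carry a small alkyl ether there on the same shared core. Nothing given here explains the size of these steps.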